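Swapping a Phenoxy for an Anilino Group

A few compounds are considered here, and "the series" means these few. Any claim that something is new, unique, unknown or untested is made for them only; others in the source may bear on it.

Of the compounds shown here, two have so far been tested in an ADME assay on microsomes from liver (Homo sapiens) for metabolic stability, read by LC-MS, using NADPH, with stated times of 5 min and 30 min, tested at 1 uM; a higher number here means faster removal of the compound, a lower number slower removal. Compound 1, `Cn1cc(-c2cnc(NCc3c(F)ccc4c3CCO4)c3cn[nH]c(=O)c23)cn1`, gives 21 mL.min-1.g-1 in this assay. Compound 2, `Fc1ccc2c(c1CNc1ncc(Oc3ccccc3)c3nncn13)CCO2`, gives 18 mL.min-1.g-1 in this assay. These two numbers lie within the scatter of each other, so compound 2 stands level with compound 1 and nothing separates the two.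

Compound 3, `Fc1ccc2c(c1CNc1ncc(Nc3ccccc3)c3nncn13)CCO2`, is the next compound to be measured. Compared with compound 2 it carries a single change: anilino in place of phenoxy on an aromatic carbon. Both groups are of the same size, each built on one six-membered ring of carbon, and the rest of the molecule is untouched.

Going by the values given here, no step between measured compounds is known here, so there is nothing to show what this exchange does to clearance. The expected step from compound 2 to compound 3 is therefore a 1.1-fold higher number from compound 2 to compound 3 (0.05 log units; within the scatter), which lies within the scatter and points in no particular direction. On that basis compound 3 is expected to give about 20 mL.min-1.g-1 in this assay, with a likely range from 9 mL.min-1.g-1 to 45 mL.min-1.g-1.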

Compound 3, intrinsic clearance in microsomes: 20 mL.min-1.g-1
Compound 3: the middle estimate sits on the measured number at the digits printed, and the stated range covers the measured number.
By their numbers in this assay, from the lowest: compounds 2, 3 and 1 (each within the scatter of the next).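

In this assay, going by these compounds alone, the exchange of phenoxy for anilino on this aromatic carbon gives a 1.1-fold higher number from compound 2 to compound 3 (0.05 log units; within the scatter), the first measured step at this place on the molecule. It shows that, for this read-out and on this core, the atom joining the carbon ring to the core can be oxygen or nitrogen with no difference that stands out from the scatter, even though the anilino group carries a hydrogen-bond donor and the phenoxy group carries none. Nothing at hand bears on why the two compounds stand level.

One exchange says little about how much freedom this place allows overall, since compound 2 and compound 3 both keep an unsubstituted carbon ring held by a single atom, and a benzyl group, a morpholine or a carboxylic acid at the same carbon could behave quite differently. From the compounds shown here alone, it also remains open whether the same exchange would stay as quiet on a different core, or with a substituent such as a chlorine or a methoxy group on the carbon ring.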